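A few compounds are considered here, and "the series" means these few. Any claim that something is new, unique, unknown or untested is made for them only; others in the source may bear on it.

In an ADME assay on MCF7-DOX cells (Homo sapiens) for cytotoxicity, read by MTT assay, with a stated time of 48 h (a lower number here means a stronger inhibitor, a higher number a weaker inhibitor), compound 1 (`COc1cc(O)c(C(=O)/C=C/c2cccc(N3CCN(C)CC3)c2)c(OC)c1`) gives 62200 nM and compound 2 (`COc1cc(O)c(C(=O)/C=C/c2cccc(N3CCN(C(=O)OC(C)(C)C)CC3)c2)c(OC)c1`) gives 56700 nM, two values within the scatter of each other. Compound 3 (`COc1cc(OC)c(C(=O)/C=C/c2cccc(N3CCN(C)CC3)c2)c(O)c1CC=C(C)C`) carries one change on compound 1: 3-methylbut-2-en-1-yl in place of hydrogen on an aromatic carbon. Within the data shown here, the only measured step, a 1.1-fold lower number from compound 1 to compound 2 (0.04 log units; within the scatter), concerns an amine nitrogen in a ring, not an aromatic carbon, so it offers little guidance here. A moderate step to a lower number is expected in this assay, with wide uncertainty. For compound 3 the expected value is 32000 nM, estimated to lie between 12000 nM and 75000 nM.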

Compound 3, half-maximal inhibitory concentration: > 100000 nM
Compound 3 gave a limit, no number (the forecaster's own chance of this, stated with the estimate: 5%); at least 3.1-fold (0.49 log units) between middle value and limit.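

Among these compounds, on this aromatic carbon, ortho to a hydroxy group and para to a methoxy group, 3-methylbut-2-en-1-yl brought no shift toward a lower number in this assay (an at least 1.6-fold higher number from compound 1 to compound 3 (0.20 log units; that floor lies within the scatter)), the first reading at this position. Compound 3 gives a limit, not a number: the limit of > 100000 nM in this assay, at which 1 of the 3 values shown sits. As far as these compounds go, only a floor can be read for this change, and that floor lies within the scatter, so the true size of the step remains unknown.

The compounds shown leave open how an ethyl chain or an aminomethyl group would read on this same aromatic carbon.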